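The source may report more compounds than this note shows. Statements on the series, on what has been measured and on what is new or still open speak of the compounds shown alone.

In a functional assay on EBC-1 cells (Homo sapiens) for antiproliferative activity, with a stated time of 72 h (a higher number here means a weaker inhibitor, a lower number a stronger inhibitor), the measured compounds gave:

- Compound 1 `N#Cc1ccc(-c2cc(F)c3ncc(Cc4ccc5ncccc5c4)n3c2)cc1F`: 145 nM
- Compound 2 `O=C(c1ccc(-c2cc(F)c3ncc(Cc4ccc5ncccc5c4)n3c2)cc1F)N1CCC2(COC2)C1`: 406 nM
- Compound 3 `CN(C)CCNC(=O)c1ccc(-c2cc(F)c3ncc(Cc4ccc5ncccc5c4)n3c2)cc1F`: 49 nM

Compound 3 has the lowest number of the three, so it is the strongest inhibitor of this small set. Compound 4 `O=C(NCCCN1CCCC1)c1ccc(-c2cc(F)c3ncc(Cc4ccc5ncccc5c4)n3c2)cc1F` departs from it by one change: (pyrrolidin-1-yl)methyl in place of dimethylamino on a saturated chain carbon, two bonds along the chain from an amide-type nitrogen. Read one bond further out, 2-(dimethylamino)ethyl becomes 3-(pyrrolidin-1-yl)propyl, while the amide and the shared core stay the same.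

Among the measured compounds shown here, two measured steps bear on this change: a 3.0-fold lower number from compound 1 to compound 3 (0.47 log units; beyond the scatter) and an 8.3-fold lower number from compound 2 to compound 3 (0.92 log units; beyond the scatter). For the measured compounds named here, both replace the whole group at that site, and no measured pair varies the chain itself, so they guide the estimate only loosely. Compound 4 keeps the amide-linked chain ending in a nitrogen group of compound 3, which gave 49 nM, so no step beyond the scatter is expected. The expected change is a 1.1-fold higher number from compound 3 to compound 4 (0.05 log units; within the scatter). For compound 4, the estimated value in this assay is 55 nM, with an expected range of 20 nM to 140 nM.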

Compound 4, half-maximal inhibitory concentration: 161 nM
Compound 4: middle estimate off by 2.9-fold (0.47 log units), on the low side; measured number above the stated range.
By their numbers in this assay, from the lowest: compound 3; then compounds 1 and 4 (each within the scatter of the next); then compound 2.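

In this assay, the amide and a chain ending in a nitrogen group do not by themselves preserve the number of compound 3: 3-(pyrrolidin-1-yl)propyl in place of 2-(dimethylamino)ethyl gives a 3.3-fold higher number from compound 3 to compound 4 (0.52 log units; beyond the scatter). The new chain still gives a 2.5-fold lower number from compound 2 to compound 4 (0.40 log units; beyond the scatter), whereas against the nitrile it gives a 1.1-fold higher number from compound 1 to compound 4 (0.05 log units; within the scatter), so the separation from the nitrile seen with compound 3 is absent for compound 4. Nothing available explains the loss seen with this change.

This step alters chain length and the amine together, and the compounds shown do not separate the two; 3-(dimethylamino)propyl or 2-(pyrrolidin-1-yl)ethyl on the same amide would do so. On these data alone, how a chain ending in a morpholine would read here also remains open.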